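Fluoro on the phenyl of compound 2

The compounds below may be only part of what the source reports. "The series", "measured", "known", "first", "only" and "open" are said of these compounds alone.

In a functional assay on B16-F10 cells (Mus musculus) for inhibition, read by colorimetric assay and MTT assay, with a stated time of 72 h (a lower number here means a stronger inhibitor, a higher number a weaker inhibitor), compound 1 `C/C1=C\CC[C@@]2(C)O[C@@H]2[C@H]2OC(=O)[C@@H](CN3CCN(C)CC3)[C@@H]2C[C@H]1O` gives 25000 nM, and compound 2 `C/C1=C\CC[C@@]2(C)O[C@@H]2[C@H]2OC(=O)[C@@H](CN3CCN(c4ccccc4)CC3)[C@@H]2C[C@H]1O` gives 6000 nM, the lower of the two numbers. Compound 3 `C/C1=C\CC[C@@]2(C)O[C@@H]2[C@H]2OC(=O)[C@@H](CN3CCN(c4ccccc4F)CC3)[C@@H]2C[C@H]1O` changes one place in compound 2: fluoro in place of hydrogen on an aromatic carbon, ortho to a large group. Going by the values given here, the one measured step, a 4.2-fold lower number from compound 1 to compound 2 (0.62 log units; beyond the scatter), is modest and beyond the scatter, and it put phenyl in place of methyl on an amine nitrogen in a ring. Among the compounds with values here, no measurement yet covers a substituent on that phenyl, so no change beyond the scatter is expected in this assay. The expected step is a 1.2-fold lower number from compound 2 to compound 3 (0.08 log units; within the scatter). For compound 3 the estimated value is 5000 nM, with an expected range of 2500 nM to 10000 nM.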

Compound 3, half-maximal inhibitory concentration: 6000 nM
Compound 3: the middle estimate sits 1.2-fold (0.08 log units) below what was measured; measured number inside the range.
By their numbers in this assay, from the lowest: compounds 2 and 3 (each within the scatter of the next); then compound 1.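

In this assay, fluoro on an aromatic carbon ortho to a large group leaves the number in place, with no change at the digits printed from compound 2 to compound 3 (within the scatter), so this position accepts the change without a shift beyond the scatter. The 2-fluorophenyl keeps the lower number gained with phenyl in place of methyl on the amine nitrogen, with a 4.2-fold lower number from compound 1 to compound 3 (0.62 log units; beyond the scatter). No evidence at hand bears on this result. Still open, on these data alone, is whether a larger group at this place, such as methoxy, trifluoromethyl or a carboxylic acid, moves the number. Fluoro on the other carbons of the phenyl also remains open.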